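The source may hold more compounds than are shown below. What is called first, only, known or untested is meant among the compounds shown, and "the series" means these compounds.

Working notes on the series

Among the measured compounds shown here, in an assay on HEK293 cells for displacement of a labelled ligand from Melanocortin receptor 4 (Homo sapiens) (on this read-out lower numbers stand for stronger inhibition and higher numbers for weaker inhibition), compound 3 `CC(C)C[C@H](N)c1cc(C(F)(F)F)ccc1N1CCN(C(=O)COc2ccc([N+](=O)[O-])cc2)CC1` gives 3100 nM and stands lowest of the two numbers in hand, with compound 2 `COc1ccc(OCC(=O)N2CCN(c3ccc(C(F)(F)F)cc3[C@@H](N)CC(C)C)CC2)cc1` nearest at 3800 nM; the single step between them, a 1.2-fold lower number from compound 2 to compound 3 (0.09 log units; within the scatter), lies within the scatter. For the measured compounds named here, compound 1 `CC(C)C[C@H](N)c1cc(C(F)(F)F)ccc1N1CCN(C(=O)C(C)Cc2ccc(Cl)c(Cl)c2)CC1` carries a branched alkyl group on the carbonyl carbon and gives 120 nM; 1600 nM (2 entries) in this assay; the spread of its entries the several entries of compound 1 in this assay, 120 nM; 1600 nM (2 entries) is wide and no step to compound 3 or compound 4 is computed for it. The step to compound 4 `COc1ccc(CC(C)C(=O)N2CCN(c3ccc(C(F)(F)F)cc3[C@@H](N)CC(C)C)CC2)cc1F` is 1-(3-fluoro-4-methoxybenzyl)ethyl in place of (4-nitrophenoxy)methyl on a carbonyl carbon. Going by the values given here, only the step from compound 2 to compound 3 is measured, and it bears little on this change, since it moves a substituent on the aromatic ring while the change to compound 4 replaces the whole group on the carbonyl carbon. The numbers of compound 1 show that a branched alkyl group at this position can go with a lower number than either aryloxy methyl analogue. For compound 4 a lower number is therefore expected, with the step of a 5.2-fold lower number from compound 3 to compound 4 (0.71 log units; beyond the scatter), and the estimate for compound 4 is 600 nM, expected between 150 nM and 2500 nM.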

Compound 4, inhibition constant: 200 nM
Estimate against measurement, compound 4: 3.0-fold (0.48 log units) above; the measured number falls inside the stated range.
By their numbers in this assay, from the lowest: compound 4; then compounds 3 and 2 (each within the scatter of the next).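

Among the compounds shown here, on the carbonyl carbon, the change from an aryloxymethyl group to 1-(3-fluoro-4-methoxybenzyl)ethyl is the first step in this assay that lies beyond the scatter: a 16-fold lower number from compound 3 to compound 4 (1.19 log units; beyond the scatter), and a 19-fold lower number from compound 2 to compound 4 (1.28 log units; beyond the scatter). The two steps agree whichever aryloxymethyl compound they start from, and both are far larger than the ring substituent exchange, a 1.2-fold lower number from compound 2 to compound 3 (0.09 log units; within the scatter), so among the compounds shown this position moves the number and that ring substituent does not. Compound 1 also carries a branched group at this position, but it gives no firm reference level, as its entries are widely spread: the several entries of compound 1 in this assay, 120 nM; 1600 nM (2 entries)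

The compounds shown leave open which part of the entering group carries the step: the branch, the loss of the ether oxygen, or the fluoro and methoxy pair on the ring. They also leave open how a carboxylic acid or a longer chain on this carbonyl carbon would read.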